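The source may report more compounds than this note shows. Statements on the series, on what has been measured and on what is new or still open speak of the compounds shown alone.

In a functional assay on HCT-116 cells (Homo sapiens) for inhibition, read by MTT assay, with a stated time of 2 days, tested at 10 uM (a lower number here means less inhibition, a higher number more inhibition at the concentration tested (going by the name of the read-out)), compound 2 `COc1cc(OC)cc(-c2cn(-c3ccc(O)c(C(=O)OCCCc4ccccc4)c3)nn2)c1` gives 19%. Compound 1 `O=C(OCCCc1ccccc1)c1cc(-n2cc(-c3cccc(O)c3)nn2)ccc1O` differs from compound 2 by 3-hydroxyphenyl in place of 3,5-dimethoxyphenyl on an aromatic carbon, and in this assay compound 1 gives 11%, a step of a number 8 percentage points lower from compound 2 to compound 1 (within the scatter). Compound 3 `COc1cc(OC)cc(-c2cn(-c3ccc(O)c(C(=O)Nc4cccc(C(F)(F)F)c4)c3)nn2)c1` has a different core, the difference being ((3-(trifluoromethyl)phenyl)amino in place of 3-phenylpropoxy on a carbonyl carbon); in this assay compound 3 gives 62%, a step of a number 43 percentage points higher from compound 2 to compound 3 (beyond the scatter), the highest of the three numbers. Compound 4 `O=C(Nc1cccc(C(F)(F)F)c1)c1cc(-n2cc(-c3cccc(O)c3)nn2)ccc1O` differs from compound 3 by 3-hydroxyphenyl in place of 3,5-dimethoxyphenyl on an aromatic carbon, the same change as that made from compound 2 to compound 1, now on the core of compound 3; it occurs twice among these compounds. The step to compound 4 is expected to be a number 7 percentage points lower from compound 3 to compound 4 (within the scatter), small like the earlier one, because the earlier step was a number 8 percentage points lower from compound 2 to compound 1 (within the scatter). Compound 4 is estimated at 55%, between 35% and 72%.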

Compound 4, a percentage reported as inhibition, at one concentration (the size of the read-out at that concentration, not a potency): 25%
Estimate against measurement, compound 4: 30 percentage points above, and the stated range ends above it.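

In this assay, 3-hydroxyphenyl in place of 3,5-dimethoxyphenyl gives a number 37 percentage points lower from compound 3 to compound 4 (beyond the scatter), so the change does not carry over from one core to the other at a constant size: the same change on two cores in this assay, a number 8 percentage points lower (within the scatter) from compound 2 to compound 1 and a number 37 percentage points lower (beyond the scatter) from compound 3 to compound 4, 29 percentage points apart, beyond the scatter of two such steps. Its size here depends on the core it is made on, with a large loss on the core of compound 3 and none that stands out from the scatter on the core of compound 1. For the compounds shown here, this rests on only two pairs, however, and it shows neither which feature of the two cores is responsible nor what the change would do on a third core.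

The compounds shown leave open how either core would respond if an amine or a carboxylic acid stood on the aromatic carbon in place of these aryl groups. They also leave open whether a longer chain on the carbonyl carbon would alter the size of the step.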